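This account rests on a few compounds, and the source may have more. Where it says the series, first, only, none or still open, it means among the compounds named here.

In a functional assay on MCF7 cells (Homo sapiens) for inhibition, read by MTT assay, with a stated time of 4 days (a higher number here means a weaker inhibitor, a lower number a stronger inhibitor), compound 1 (`COc1cc(NC(C)CCCNC(=O)NNC(=O)NCCCCCO)c2ncccc2c1`) gives 4000 nM and compound 2 (`COc1cc(NC(C)CCCNC(=O)NNC(=O)Nc2ccc(Cl)c(C(F)(F)F)c2)c2ncccc2c1`) gives 2000 nM. Among the compounds with values here, with only these two values measured, compound 1 stands within the scatter of its sole neighbour.

Compound 3 (`COc1cc(NC(C)CCCNC(=O)NN)c2ncccc2c1`) differs from compound 1 by hydrogen in place of (5-hydroxypentyl)carbamoyl on an amine nitrogen.

Within the data shown here, one measured step bears on this change, and only indirectly. The step of a 2.0-fold lower number from compound 1 to compound 2 (0.30 log units; within the scatter) exchanges 5-hydroxypentyl for 4-chloro-3-(trifluoromethyl)phenyl on an amide-type nitrogen, within the same part of the molecule. Even that exchange of end groups stays within the scatter, so no step beyond the scatter is expected in this assay. However, no measured pair removes the whole (5-hydroxypentyl)carbamoyl group, which leaves the direction open and calls for a wide range, with only a slight lean towards a higher number.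

The expected change is a 1.3-fold higher number from compound 1 to compound 3 (0.10 log units; within the scatter), an estimate that stays within the scatter. For compound 3 the estimated value is 5000 nM, with an expected range of 1500 nM to 20000 nM.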

Compound 3, half-maximal inhibitory concentration: 16000 nM
Beside the measured number, compound 3's estimate is 3.2-fold (0.51 log units) below it; low and high end bracket the measured number.
By their numbers in this assay, from the lowest: compounds 2 and 1 (each within the scatter of the next); then compound 3.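

In this assay, within the data shown here, taking the whole (5-hydroxypentyl)carbamoyl group off the amine nitrogen gives a 4.0-fold higher number from compound 1 to compound 3 (0.60 log units; beyond the scatter), the only step so far that lies beyond the scatter. Among these compounds, the one earlier step, a 2.0-fold lower number from compound 1 to compound 2 (0.30 log units; within the scatter), only exchanged the end group and kept the carbamoyl unit, whereas this result shows that the position is not indifferent to losing the group altogether, with compound 3, which ends in a plain amino group on this side, the weaker inhibitor of the pair by a modest margin. Nothing in hand bears on the origin of this difference.

The compounds shown leave open whether the carbonyl alone accounts for the step or the attached chain also contributes, a question that an acetyl or a methylcarbamoyl group on the same amine nitrogen would help to separate. Also open, going by these compounds, is how much the far end of the group can vary, for example with a terminal amine or a carboxylic acid in place of the hydroxyl of the 5-hydroxypentyl chain.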